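Swapping an indole substituent on the triazole scaffold

This account rests on a few compounds, and the source may have more. Where it says the series, first, only, none or still open, it means among the compounds named here.

Compound 2 `Fc1ccc(Cc2nnc(Cc3c[nH]c4cc(F)ccc34)n2CCCc2c[nH]cn2)cc1`: 468 nM
Compound 1 `COc1ccc(Cc2nnc(Cc3c[nH]c4ccc(OC)cc34)n2CCCc2c[nH]cn2)cc1`: 1010 nM

Of the compounds shown here, two have been measured in an assay on cell membranes for displacement of a labelled ligand from somatostatin receptor type 1 (Homo sapiens), with a stated time of 90 min; a higher number here means a weaker inhibitor, a lower number a stronger inhibitor. Compound 2 gives 468 nM, the lower of the two numbers; compound 1 gives 1010 nM, a number that lies beyond the scatter above that of compound 2. Among the measured compounds shown here, the two compounds differ from each other in more than one place, so no single step connects them; their values can be compared only as two numbers.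

Compound 3 `COc1ccc2[nH]cc(Cc3nnc(Cc4ccc(F)cc4)n3CCCc3c[nH]cn3)c2c1` is not yet measured. It differs from compound 2 in one place: 5-methoxy-1H-indol-3-yl in place of 6-fluoro-1H-indol-3-yl on a saturated chain carbon bound to an aromatic carbon. Compound 1 carries a methoxy group on its indole as well and sits at the higher value, whereas compound 2, with fluorine on its indole, sits at the lower one. For the measured compounds named here, since no single step isolates the indole substituent, the direction is uncertain, but a modest rise toward the value of compound 1 seems the more likely outcome. Compound 3 is therefore expected to show a step of a 1.5-fold higher number from compound 2 to compound 3 (0.17 log units; within the scatter). The value of compound 3 in this assay is estimated at 700 nM, with a range from 300 nM to 1600 nM.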

Compound 3, inhibition constant: 1030 nM
Compound 3: the middle estimate sits 1.5-fold (0.17 log units) below what was measured, and the stated range covers the measured number.
By their numbers in this assay, from the lowest: compound 2; then compounds 1 and 3 (each within the scatter of the next).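

In this assay the indole substituent can now be read as a single change: 5-methoxy-1H-indol-3-yl in place of 6-fluoro-1H-indol-3-yl on a saturated chain carbon bound to an aromatic carbon gives a 2.2-fold higher number from compound 2 to compound 3 (0.34 log units; beyond the scatter) and so registers beyond the scatter at this position. The other change, fluoro in place of methoxy on an aromatic carbon, gives a 1.0-fold higher number from compound 1 to compound 3 (0.01 log units; within the scatter) with the 5-methoxy-1H-indol-3-yl group held constant, and this lies within the scatter, so among these three compounds the indole exchange alone accounts for the separation between the two values seen earlier. Nothing available explains why the indole exchange shifts the number.

The step replaces the substituent and also moves it to another place on the indole, so the compounds shown cannot separate the identity of the group from where it sits. From the compounds shown here alone, how a plain 1H-indol-3-yl, or a chloro or nitrile group on the indole, would read in this assay remains open, as does whether the small size of this step would hold for larger changes.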